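The compounds below may be only part of what the source reports. "The series", "measured", "known", "first", "only" and "open" are said of these compounds alone.

Measured so far:
- compound 1 `Cc1cc(=O)oc2cc(Sc3cccc(Cl)n3)ccc12`: 920 nM
- compound 2 `Cc1cc(=O)oc2cc(SCc3cccc(C#N)c3)ccc12`: > 32500 nM
- compound 3 `COc1cc(CSc2ccc3c(C)cc(=O)oc3c2)cc(OC)c1`: > 29200 nM

In a functional assay on KBVIN cells (Homo sapiens) for antiproliferative activity, read by sulforhodamine B assay, with a stated time of 72 h (a lower number here means a stronger inhibitor of growth, a higher number a weaker inhibitor of growth), compound 1 gives 920 nM. Compound 2 reaches only a limit of the assay, > 32500 nM, and stands there with no number of its own. Compound 3 likewise gives only a limit, > 29200 nM. Compound 4 `Cc1cc(=O)oc2cc(SCc3cccc(OC(F)(F)F)c3)ccc12` has not been measured. It differs from compound 2 by trifluoromethoxy in place of cyano on an aromatic carbon. Since compound 2 sits at a limit of > 32500 nM in this assay, at which 1 of the 3 values shown sits, and compound 3 at a limit (the limit of > 29200 nM in this assay, at which 1 of the 3 values shown sits), a step of no clear size or direction is expected from compound 2 to compound 4. Compound 4 is therefore estimated at 30000 nM, within 8000 nM to 90000 nM, most likely again as a limit; the expected step is an at least 1.0-fold lower number from compound 2 to compound 4 (0.03 log units; that floor lies within the scatter).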

Compound 4, concentration for 50% growth inhibition: 15300 nM
For compound 4 the middle estimate is 2.0-fold (0.29 log units) above the measured one; low and high end bracket the measured number.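

In this assay, compound 4 gives 15300 nM, a true number rather than a limit of the assay. Trifluoromethoxy in place of cyano, on an aromatic carbon meta to a large group, gives an at least 2.1-fold lower number from compound 2 to compound 4 (0.32 log units; beyond the scatter), so the read-out does respond to the group at this position. Only a floor for that step can be read because compound 2 stands at a limit, not at a number: the limit of > 32500 nM in this assay, at which 1 of the 4 values shown sits.

Going by these compounds, whether an amine or a carboxylic acid at this same place would lower the number further stays open. So does whether trifluoromethoxy would give a similar step on another carbon of this ring.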